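Oxolan-3-yl in place of benzyl: an expected step

A few compounds are considered here, and "the series" means these few. Any claim that something is new, unique, unknown or untested is made for them only; others in the source may bear on it.

Measured in a physicochemical assay for lipophilicity, at pH 7.4; on this read-out higher numbers stand for higher lipophilicity and lower numbers for lower lipophilicity:
compound 1 `Cc1cc(C(=O)Nc2ccc(F)cc2)nn1Cc1cc(Cl)ccc1OCc1ccccc1`: 3
compound 2 `Cc1cc(NC(=O)OCc2ccccc2)nn1Cc1cc(Cl)ccc1OCc1ccccc1`: 3.1

Compound 2, at 3.1, stands within the scatter of compound 1. Compound 3 `Cc1cc(NC(=O)O[C@H]2CCOC2)nn1Cc1cc(Cl)ccc1OCc1ccccc1`, not yet measured, carries oxolan-3-yl in place of benzyl on an oxygen next to a carbonyl group. Among the measured compounds shown here, the one measured step, a number 0.10 log units higher from compound 1 to compound 2 (within the scatter), exchanged other groups, so it gives no direct size for this change. With one six-membered aromatic ring of carbon only leaving, a step to lower numbers beyond the scatter is expected in this assay. The expected step is a number 0.80 log units lower from compound 2 to compound 3 (beyond the scatter). Compound 3 is estimated at 2.3, with an expected range of 1.8 to 2.8.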

Compound 3, distribution coefficient: 2.7
Beside the measured number, compound 3's estimate is 0.40 log units below it; low and high end bracket the measured number.
By their numbers in this assay, from the lowest: compounds 3, 1 and 2 (each within the scatter of the next, the first and the last beyond it).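

On the oxygen next to a carbonyl group, oxolan-3-yl in place of benzyl gives the first direct size for this change in this assay: a number 0.40 log units lower from compound 2 to compound 3 (beyond the scatter). The exchange of the whole (4-fluorophenyl)carbamoyl for (((oxolan-3-yl)oxy)carbonyl)amino gives a number 0.30 log units lower from compound 1 to compound 3 (within the scatter), so these two compounds are not told apart. Nothing measured here accounts for the size of either step.

The compounds shown leave open how a methoxyethyl chain or a piperidinyl group would read on the same oxygen. They also leave open whether the opposite stereocentre of oxolan-3-yl would give the same number.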